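The source may report more compounds than this note shows. Statements on the series, on what has been measured and on what is new or still open speak of the compounds shown alone.

Working notes on the series. In a functional assay on HCT-116 cells (Homo sapiens) for inhibition, read by MTT assay, with a stated time of 48 h (on this read-out higher numbers stand for weaker inhibition and lower numbers for stronger inhibition), compound 1 `COc1ccc(CNc2cc(OC)c(OC)c(OC)c2)cc1Br` gives 48100 nM, compound 3 `COc1ccc(CNc2cc(OC)c(OC)c(OC)c2)cc1N` gives 8270 nM and compound 2 `C=C(C)C(=O)N(Cc1ccc(OC)c(O)c1)c1cc(OC)c(OC)c(OC)c1` gives 200 nM, the lowest of the three numbers shown; its gaps to compound 3 and to compound 1 both lie beyond the scatter. Among the compounds with values here, the only measured step, a 5.8-fold lower number from compound 1 to compound 3 (0.76 log units; beyond the scatter), concerns a substituent on an aromatic carbon and does not bear on the change now in view. Compound 4 `C/C=C/C(=O)N(Cc1ccc(OC)c(O)c1)c1cc(OC)c(OC)c(OC)c1` differs from compound 2 by prop-1-en-1-yl in place of 1-methylethenyl on a carbonyl carbon. Within the data shown here, no measured step addresses this change, so the expected step in this assay, a 1.5-fold higher number from compound 2 to compound 4 (0.18 log units; within the scatter), is none beyond the scatter. Compound 4 is therefore estimated at 300 nM in this assay, with a range from 100 nM to 900 nM.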

Compound 4, half-maximal inhibitory concentration: 55 nM
Estimate against measurement, compound 4: 5.5-fold (0.74 log units) above, and the stated range ends above it.
By their numbers in this assay, from the lowest: compound 4; then compound 2; then compound 3; then compound 1.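

The two groups on the carbonyl carbon have the same atoms, joined differently, yet in this assay the change gives a clear step (a 3.6-fold lower number from compound 2 to compound 4 (0.56 log units; beyond the scatter)). This place therefore responds to how the three carbons are arranged and not only to how many there are, which the earlier step on an aromatic carbon could not show. Nothing at hand accounts for this step. As far as these compounds go, whether a saturated propyl or a longer chain on this carbonyl carbon would match prop-1-en-1-yl stays open. So does whether a double bond in this group matters at all.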